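The compounds below may be only part of what the source reports. "The series", "measured", "known", "first", "only" and "open" are said of these compounds alone.

The study follows a set of compounds that share one core and differ in the aromatic groups attached to it. Compound 1 `Oc1ccc(-c2cc(-c3cccnc3)nc(-c3ccccc3Cl)c2)cc1` gives 0.9% in an assay on isolated protein for inhibition of DNA topoisomerase 1 (Homo sapiens), with a stated time of 30 min, tested at 100 uM; a higher number here means a stronger effect of the compound at the concentration tested, a lower number a weaker effect. Compound 2 `Oc1ccc(-c2cc(-c3cccc(Cl)c3)nc(-c3ccccn3)c2)cc1` gives 59.4% in this assay, and compound 3 `Oc1ccc(-c2cc(-c3cccc(Cl)c3)nc(-c3ccco3)c2)cc1` gives 25.5% in this assay. Compound 3 thus stands second highest of the three numbers: below compound 2 and above compound 1, with both gaps beyond the scatter.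

The next compound, compound 4 `Oc1ccc(-c2cc(-c3cccnc3)nc(-c3cccc(Cl)c3)c2)cc1`, differs from compound 3 in one place: pyridin-3-yl in place of furan-2-yl on an aromatic carbon.

Among the compounds with values here, only one measured step speaks to this change. The step of a number 33.9 percentage points lower from compound 2 to compound 3 (beyond the scatter) shows that exchanging a six-membered ring with one nitrogen for furan-2-yl at this position lowered the read-out by a large margin. Compound 4 goes the other way, returning a six-membered ring with one nitrogen, so a rise in this assay is expected. Within the data shown here, the caution is compound 1, which also carries pyridin-3-yl and gives a very low number, though it differs from compound 4 in the chlorophenyl group and no single step links it to the others. Weighing these, the step of a number 16.5 percentage points higher from compound 3 to compound 4 (beyond the scatter) is expected to be upward, and compound 4 is estimated to give 42% in this assay, within a range from 12% to 68%.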

Compound 4, a percentage reported as inhibition, at one concentration (the size of the read-out at that concentration, not a potency): 55.2%
Compound 4: the middle estimate sits 13.2 percentage points below what was measured; measured number inside the range.
By their numbers in this assay, from the lowest: compound 1; then compound 3; then compounds 4 and 2 (each within the scatter of the next).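

With compound 4, three different groups have been read at this position, next to the ring nitrogen, in this assay: pyridin-3-yl in place of furan-2-yl gives a number 29.7 percentage points higher from compound 3 to compound 4 (beyond the scatter), a rise that stands against the fall seen in a number 33.9 percentage points lower from compound 2 to compound 3 (beyond the scatter). The two pyridinyl groups cannot be told apart here, as pyridin-3-yl in place of pyridin-2-yl gives a number 4.2 percentage points lower from compound 2 to compound 4 (within the scatter), so moving the nitrogen within this ring leaves the read-out within the scatter for this pair. The very low number of compound 1 also no longer counts against pyridin-3-yl, since with that group kept, 3-chlorophenyl in place of 2-chlorophenyl gives a number 54.3 percentage points higher from compound 1 to compound 4 (beyond the scatter), which shows that the place of the chlorine on the phenyl group can by itself decide the read-out.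

Still open, on these data alone, is whether a group of another kind at this position, such as an amine or a carboxylic acid, would keep the read-out, and whether the preference for 3-chlorophenyl over 2-chlorophenyl holds with pyridin-2-yl or furan-2-yl in place of pyridin-3-yl. Nothing available here gives a reason for any of these differences.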